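Swapping the thiazolylamino arm of compound 2 for a methylimidazole

The source may report more compounds than this note shows. Statements on the series, on what has been measured and on what is new or still open speak of the compounds shown alone.

Compound 1 `CCC(CC)(c1nnc[nH]1)c1ccc(-c2ccc3cc(F)cc(F)c3c2)[nH]c1=O` gives 350 nM in a functional assay on CHO cells for antagonist activity at prostaglandin E2 receptor EP3 subtype (Homo sapiens), read by cAMP accumulation; a lower number here means a stronger inhibitor, a higher number a weaker inhibitor; compound 2 `CC(C)C(Nc1nccs1)c1ccc(-c2ccc3cccc(F)c3c2)[nH]c1=O` gives 10 nM; compound 3 `CCn1ncc2c(F)cc(-c3ccc(C(CC)(CC)c4ncn(C)n4)c(=O)[nH]3)cc21` gives 96 nM.

Of the three measured compounds, compound 2 has the lowest number in this assay, and its gaps to compound 3 and to compound 1 both lie beyond the usual scatter. Compound 4 `Cc1c[nH]c(C(c2ccc(-c3ccc4cccc(F)c4c3)[nH]c2=O)C(C)C)n1` is not yet measured. It differs from compound 2 in one place: 4-methyl-1H-imidazol-2-yl in place of (1,3-thiazol-2-yl)amino on a saturated chain carbon bound to an aromatic carbon and a saturated chain carbon. Going by the values given here, no pair of measured compounds shows this change alone, so its effect is open. A moderate weakening beyond the scatter is expected, since compound 1, which also carries a directly attached five-membered ring, gives 350 nM. Compound 4 is estimated at 30 nM, between 8 nM and 120 nM, an expected step of a 3.0-fold higher number from compound 2 to compound 4 (0.48 log units; beyond the scatter).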

Compound 4, half-maximal inhibitory concentration: 36 nM
Beside the measured number, compound 4's estimate is 1.2-fold (0.08 log units) below it; low and high end bracket the measured number.
By their numbers in this assay, from the lowest: compound 2; then compound 4; then compound 3; then compound 1.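

Going by these compounds alone, putting 4-methyl-1H-imidazol-2-yl in place of (1,3-thiazol-2-yl)amino on this saturated chain carbon gives a 3.6-fold higher number from compound 2 to compound 4 (0.56 log units; beyond the scatter) in this assay, the first comparison at this position that changes one place only. The position accepts an imidazole arm directly on the carbon, with a modest loss. The two groups match in heavy-atom count and hydrogen-bond donor count but differ in sulfur and in acceptor count, and no measurement here says what drives the step.

Still open, as far as these compounds go, is how an unsubstituted 1H-imidazol-2-yl, a plain amine or a carboxylic acid on this carbon would compare with compound 2.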